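Notes on the series: from compound 2 to compound 3

The compounds below may be only part of what the source reports. "The series", "measured", "known", "first", "only" and "open" are said of these compounds alone.

Values in a functional assay on HL-60 cells (Homo sapiens) for antiproliferative activity, read by sulforhodamine B assay, with a stated time of 72 h; on this read-out higher numbers stand for weaker inhibition and lower numbers for stronger inhibition:
- compound 1 `Fc1ccccc1NC(=S)N/N=C/c1ccc2ccccc2n1`: > 100000 nM (a limit, not a number)
- compound 2 `S=C(N/N=C/c1ccc2ccccc2n1)Nc1cccc(Cl)c1`: 28800 nM

Among the compounds with values here, compound 2 carries the only actual number so far, at 28800 nM. Compound 1 is reported only as a limit, > 100000 nM.

The next compound is compound 3 `COc1ccc(NC(=S)N/N=C/c2ccc3ccccc3n2)cc1`, and the change is 4-methoxyphenyl in place of 3-chlorophenyl on an amide-type nitrogen. Within the data shown here, only one measured step bears on this place, namely an at least 3.4-fold lower number from compound 1 to compound 2 (0.54 log units; beyond the scatter), where 3-chlorophenyl replaced 2-fluorophenyl on the same nitrogen. That step shows that the group here can shift the read-out in this assay. It rests on a limit, however, and neither of its groups is the one entering now, so it gives no direction for 4-methoxyphenyl. No clear move from compound 2 is therefore the working expectation, with wide uncertainty on both sides. The expected change is a 1.2-fold higher number from compound 2 to compound 3 (0.08 log units; within the scatter). For compound 3 the estimated value is 35000 nM, with an expected range from 10000 nM to 100000 nM.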

Compound 3, half-maximal inhibitory concentration: 43800 nM
Compound 3: middle estimate off by 1.3-fold (0.10 log units), on the low side, within the range that was stated.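

In this assay, 4-methoxyphenyl in place of 3-chlorophenyl on the amide-type nitrogen gives a 1.5-fold higher number from compound 2 to compound 3 (0.18 log units; within the scatter), so these two groups cannot be told apart at this position. Set against 2-fluorophenyl, 4-methoxyphenyl gives an at least 2.2-fold lower number from compound 1 to compound 3 (0.35 log units; beyond the scatter), which shows that the earlier step is not particular to 3-chlorophenyl: two different groups now stand apart from 2-fluorophenyl in the same direction. The true size of both steps stays undefined because compound 1 is reported only as a limit: the limit of > 100000 nM in this assay, at which 1 of the 3 values shown sits.

The three phenyl groups differ both in the substituent and in where it sits, so a 2-chlorophenyl or 4-chlorophenyl group would be needed to show whether the substituent or its location separates compound 1 from the other two. The compounds shown also leave open whether this nitrogen can carry anything other than a substituted phenyl, such as a cyclohexyl ring, a benzyl group or a chain ending in an amine, and whether any such group would move the read-out well beyond the scatter.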